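The source may report more compounds than this note shows. Statements on the series, on what has been measured and on what is new or still open speak of the compounds shown alone.

Measured so far:
compound 1 `O=C(Nc1ccc(Cl)cc1CN1C(=O)c2ccccc2C1=O)c1ccccc1C(F)(F)F` with 5700 nM
compound 2 `O=C(Nc1ccc(Cl)cc1CN1C(=O)c2ccccc2C1=O)c1cncs1` with 1900 nM

In an assay on CHO cells for positive allosteric modulation of metabotropic glutamate receptor 5 (Homo sapiens), read by FLIPR (on this read-out higher numbers stand for an effect only at larger amounts of compound and lower numbers for an effect already at smaller amounts), compound 2 gives 1900 nM, the lower of the two numbers seen. Compound 1 gives 5700 nM in this assay, and the step between them, a 3.0-fold lower number from compound 1 to compound 2 (0.48 log units; beyond the scatter), lies beyond the scatter. Compound 3 `COc1ccccc1C(=O)Nc1ccc(Cl)cc1CN1C(=O)c2ccccc2C1=O` has not yet been measured. It differs from compound 2 by 2-methoxyphenyl in place of 1,3-thiazol-5-yl on a carbonyl carbon. Among the compounds with values here, the only measured step that bears on this change is the one just described, a 3.0-fold lower number from compound 1 to compound 2 (0.48 log units; beyond the scatter), in which an aromatic six-membered carbon ring on the carbonyl carbon gave way to the thiazole; compound 3 reverses that kind of change, bringing back a six-membered carbon ring, though with a methoxy group rather than a trifluoromethyl group. On this single comparison the number for compound 3 is expected to rise back toward that of compound 1, a modest step of about a 2.1-fold higher number from compound 2 to compound 3 (0.32 log units; beyond the scatter). Compound 3 is therefore estimated at 4000 nM in this assay, with a likely range from 1500 nM to 11000 nM.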

Compound 3, half-maximal effective concentration: > 100000 nM
Compound 3: no number, only a limit; the forecaster's own chance of this, stated with the estimate: 10%; middle value at least 25-fold (1.39 log units) from the limit.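

In this assay compound 3 gives no number, only a limit of the assay: the limit of > 100000 nM in this assay, at which 1 of the 3 values shown sits.

Set against the thiazole on the carbonyl carbon, the 2-methoxyphenyl group gives an at least 52-fold higher number from compound 2 to compound 3 (1.72 log units; beyond the scatter), so a six-membered aromatic carbon ring at this place does not by itself fix the read-out. With that ring kept, methoxy in place of trifluoromethyl on an aromatic carbon gives an at least 17-fold higher number from compound 1 to compound 3 (1.24 log units; beyond the scatter), which shows that the group carried on the ring can move the number far more than the exchange of rings did in a 3.0-fold lower number from compound 1 to compound 2 (0.48 log units; beyond the scatter).

As far as these compounds go, it remains open whether this large rise follows the oxygen of the methoxy group or the group as a whole, a question that a hydroxy group, a methyl group or an amine on the same ring would address. Equally open, from the compounds shown here alone, is whether the lower number of compound 2 belongs to the 1,3-thiazol-5-yl group in particular or to five-membered aromatic rings more widely, as a furan or a thiophene on the same carbonyl carbon would show.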